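Chloro to Trifluoromethyl on a Longer Sulfamide Chain

The source may report more compounds than this note shows. Statements on the series, on what has been measured and on what is new or still open speak of the compounds shown alone.

Three compounds with a shared core were tested in a functional assay on MCF7 cells (Homo sapiens) for antiproliferative activity, read by sulforhodamine B assay, with a stated time of 48 h; on this read-out higher numbers stand for weaker inhibition of growth and lower numbers for stronger inhibition of growth. Compound 1 `NS(=O)(=O)NCC1CCN(c2cc(-c3ccc(Cl)cc3)ncn2)CC1` gives 25500 nM in this assay. Compound 2 `NS(=O)(=O)NCC1CCN(c2cc(-c3ccc(C(F)(F)F)cc3)ncn2)CC1` differs from compound 1 by trifluoromethyl in place of chloro on an aromatic carbon, and in this assay compound 2 gives 22500 nM; the step is a 1.1-fold lower number from compound 1 to compound 2 (0.05 log units; within the scatter). Compound 3 `NS(=O)(=O)NCCC1CCN(c2cc(-c3ccc(Cl)cc3)ncn2)CC1` differs from compound 1 by (sulfamoylamino)methyl in place of sulfamoylamino on a saturated chain carbon bound to a saturated ring carbon, and in this assay compound 3 gives 19700 nM; the step is a 1.3-fold lower number from compound 1 to compound 3 (0.11 log units; within the scatter).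

Compound 4 `NS(=O)(=O)NCCC1CCN(c2cc(-c3ccc(C(F)(F)F)cc3)ncn2)CC1` is not yet measured. It differs from compound 3 by trifluoromethyl in place of chloro on an aromatic carbon, the same change, at the same place, as between compound 1 and compound 2. Since that earlier change gave a 1.1-fold lower number from compound 1 to compound 2 (0.05 log units; within the scatter), a similarly small step is expected here, namely a 1.1-fold lower number from compound 3 to compound 4 (0.04 log units; within the scatter), resting on the value of compound 3 at 19700 nM. For compound 4 the estimate is 18000 nM, with a likely range from 9000 nM to 36000 nM.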

Compound 4, concentration for 50% growth inhibition: 15200 nM
Compound 4: the middle estimate sits 1.2-fold (0.07 log units) above what was measured; measured number inside the range.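

In this assay, trifluoromethyl in place of chloro gives a 1.3-fold lower number from compound 3 to compound 4 (0.11 log units; within the scatter), and this agrees with the same change made on the shorter chain: the same change on two cores in this assay, a 1.1-fold lower number (0.05 log units; within the scatter) from compound 1 to compound 2 and a 1.3-fold lower number (0.11 log units; within the scatter) from compound 3 to compound 4, 1.1-fold (0.06 log units) apart, within the scatter of two such steps

Putting (sulfamoylamino)methyl in place of sulfamoylamino gives a 1.5-fold lower number from compound 2 to compound 4 (0.17 log units; within the scatter), and this also agrees with the earlier step: the same change on two cores in this assay, a 1.3-fold lower number (0.11 log units; within the scatter) from compound 1 to compound 3 and a 1.5-fold lower number (0.17 log units; within the scatter) from compound 2 to compound 4, 1.1-fold (0.06 log units) apart, within the scatter of two such steps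

All of these steps lie within the scatter, so the series shows that both changes carry across these two cores without a measurable shift, but it does not show that either change has a real effect of its own.

From the compounds shown here alone, it remains open whether a nitrile or a methoxy group on the aromatic ring would move the number beyond the scatter. The same question applies to a still longer chain, or to an amine in place of the sulfamide group.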